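A few compounds are considered here, and "the series" means these few. Any claim that something is new, unique, unknown or untested is made for them only; others in the source may bear on it.

- compound 1 `OC[C@@H](O)[C@H]1O[C@@H](n2cnc3c(Cl)ncnc32)[C@H](O)[C@@H]1O` gives > 100000 nM
- compound 2 `Nc1nc(Cl)nc2c1ncn2[C@@H]1O[C@H]([C@H](O)CO)[C@@H](O)[C@H]1O` gives > 100000 nM

In a functional assay on MCF7 cells (Homo sapiens), read by colorimetric assay, with a stated time of 96 h (on this read-out higher numbers stand for weaker inhibition and lower numbers for stronger inhibition), compound 2 reads > 100000 nM and this is a limit of the assay, not a number. Compound 1 reads > 100000 nM and this too is a limit. Compound 3 `CNc1nc(Cl)nc2c1ncn2[C@@H]1O[C@H]([C@H](O)CO)[C@@H](O)[C@H]1O` differs from compound 2 by one change, amino to methylamino, with methyl in place of hydrogen on a nitrogen on an aromatic ring as the whole difference. With compound 2 at > 100000 nM as a limit, no step beyond the usual scatter is expected in this assay and another limit is the likeliest result. The estimated change is a number no higher from compound 2 to compound 3 (the limit leaves the size open) in either direction. For compound 3 the estimate is 100000 nM with an expected range of 40000 nM to 200000 nM in this read-out.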

Compound 3, half-maximal inhibitory concentration: > 100000 nM
Compound 3 gave a limit, no number; the forecaster's own chance of this, stated with the estimate: 85%; the middle value sits exactly at the limit.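

No step can be read between compound 2 and compound 3, since both results are limits and not numbers. In this assay the compounds shown leave open how strongly any of them inhibits and whether the methyl changes that at all.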